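A few compounds are considered here, and "the series" means these few. Any claim that something is new, unique, unknown or untested is made for them only; others in the source may bear on it.

Measured compounds:
Compound 1, `Cn1ccnc1[C@@H](CC(=O)O)c1ccc(OCc2cccc(-c3ccccc3S(C)(=O)=O)c2)cc1` — in an assay on CHO cells for agonist activity at Free fatty acid receptor 1 (Homo sapiens), read by luminescence, with a stated time of 20 s, in the presence of a further agent that is not named here (on this read-out lower numbers stand for an effect already at smaller amounts and higher numbers for an effect only at larger amounts of compound), compound 1 gives "not determined" (no result reported).
Compound 2, `Cn1ccnc1[C@@H](CC(=O)O)c1ccc(OCc2cccc(-c3ccc(Cl)cc3Cl)c2)cc1` — in this assay compound 2 gives 30000 nM.
Compound 3, `Cn1ccnc1[C@@H](CC(=O)O)c1ccc(OCc2cccc(-c3ccccc3Cl)c2)cc1` — in this assay compound 3 gives 56000 nM.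

Compound 3 carries the highest of the two numbers available, and its nearest neighbour is compound 2, whose step to it, a 1.9-fold higher number from compound 2 to compound 3 (0.27 log units; within the scatter), stays within the scatter, so the two compounds cannot be ordered against each other. Compound 1 adds a third structure but no number.

Compound 4, `Cc1cccc(C)c1-c1cccc(COc2ccc([C@H](CC(=O)O)c3nccn3C)cc2)c1`, differs from compound 3 in one place: 2,6-dimethylphenyl in place of 2-chlorophenyl on an aromatic carbon. Among the measured compounds shown here, the only measured step that touches this region is a 1.9-fold higher number from compound 2 to compound 3 (0.27 log units; within the scatter), in which the loss of a chloro substituent on that ring produced no change beyond the scatter. For the measured compounds named here, nothing among the measured compounds addresses a methyl-bearing ring at this position, so the expectation rests on the low sensitivity seen in that single step.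

On that basis compound 4 is expected to behave much like compound 3, with an estimated step of a 1.4-fold lower number from compound 3 to compound 4 (0.15 log units; within the scatter) that stays within the scatter. The estimate for compound 4 in this assay is 40000 nM, with a range from 10000 nM to 160000 nM.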

Compound 4, half-maximal effective concentration: 29000 nM
Estimate against measurement, compound 4: 1.4-fold (0.14 log units) above, within the range that was stated.
By their numbers in this assay, from the lowest: compounds 4, 2 and 3 (each within the scatter of the next).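

In this assay the exchange of 2-chlorophenyl for 2,6-dimethylphenyl gives a 1.9-fold lower number from compound 3 to compound 4 (0.29 log units; within the scatter) and stays within the scatter, and the exchange of 2,4-dichlorophenyl for the same group gives a 1.0-fold lower number from compound 2 to compound 4 (0.01 log units; within the scatter) and also stays within the scatter. The earlier step had only removed a chloro substituent from a ring that kept another one, whereas these two steps replace all the chlorine on that ring with two methyl groups, and the three measured compounds still cannot be ordered against one another, so this change on an aromatic carbon, meta to a large group, shows no measurable effect on the number in this small set. No evidence beyond these numbers bears on the result.

As far as these compounds go, what remains open is whether any group on this ring can move the number beyond the scatter, since the measured rings carry only chloro or methyl substituents, and a ring bearing an amine, a hydroxyl or a carboxylic acid would test a different kind of group at this place. Among the compounds shown here, the methylsulfonyl ring of compound 1 offers no comparison either, as compound 1 gives "not determined" (no result reported) in this assay and so no step to it can be read.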